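Enaminone series: chloro for methoxy in compound 4

The source may report more compounds than this note shows. Statements on the series, on what has been measured and on what is new or still open speak of the compounds shown alone.

The series shares one core, seen in compound 1 `O=C(/C=C\Nc1ccc2cc[nH]c2c1)c1nc(-c2ccc(C(F)(F)F)cc2)n2ccccc12`, compound 2 `COc1ccc(N/C=C\C(=O)c2nc(-c3ccc(F)cc3)n3ccccc23)cc1` and compound 3 `O=C(/C=C\Nc1ccc2[nH]ccc2c1)c1nc(-c2ccc(C(F)(F)F)cc2)n2ccccc12`. In a functional assay on HCT-116 cells (Homo sapiens) for cytotoxicity, read by MTT assay, with a stated time of 48 h (on this read-out higher numbers stand for weaker inhibition and lower numbers for stronger inhibition), compound 1 reaches only the limit > 30000 nM. Compound 2 likewise reaches only the limit > 30000 nM. Compound 3 gives 27100 nM, so an at least 1.1-fold lower number from compound 1 to compound 3 (0.04 log units; that floor lies within the scatter) is only a floor. Where compound 2 stands is told only by the limit of > 30000 nM in this assay, at which 2 of the 3 values shown sit. Compound 4 `O=C(/C=C\Nc1ccc(Cl)cc1)c1nc(-c2ccc(F)cc2)n2ccccc12` differs from compound 2 by chloro in place of methoxy on an aromatic carbon. Within the data shown here, no measured step touches this change, and the single step known, from compound 1 to compound 3, lies within the scatter, so no step beyond the scatter is expected in this assay. Compound 4 is expected to give 30000 nM, between 10000 nM and 100000 nM. The expected step is a number no higher from compound 2 to compound 4 (the limit leaves the size open).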

Compound 4, half-maximal inhibitory concentration: 1210 nM
Estimate against measurement, compound 4: 25-fold (1.39 log units) above, outside the stated range (below it).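

In this assay, the change from (4-methoxyphenyl)amino to (4-chlorophenyl)amino gives an at least 24-fold lower number from compound 2 to compound 4 (1.39 log units; beyond the scatter), the only step shown that lies beyond the scatter. The group para to a large group on this ring therefore matters to the read-out, which the step between the indolyl attachments did not show. The size of the step remains a floor, since one end is a limit: the limit of > 30000 nM in this assay, at which 2 of the 4 values shown sit.

From the compounds shown here alone, whether the step comes from gaining chloro or losing methoxy stays open. Fluoro, methyl or a dimethylamino group at this position would help separate the two.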